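Moving the fluorine from 3-fluorophenyl to 4-fluorophenyl on sulfur

This account rests on a few compounds, and the source may have more. Where it says the series, first, only, none or still open, it means among the compounds named here.

Of the compounds shown here, two have numbers so far in a functional assay on A549 cells (Homo sapiens) for inhibition, read by CCK-8 assay, with a stated time of 72 h, tested at 8 uM (on this read-out lower numbers stand for less inhibition of growth and higher numbers for more inhibition of growth at the one concentration tested), and neither is a single-place neighbour of the other. Compound 1 (`Nc1ccccc1NC(=O)/C=C/c1ccc(CSc2cccc(F)c2)cc1`) gives 56.6% as the lower of the two numbers. Compound 2 (`COc1ccc(SCc2ccc(C(=O)Nc3ccccc3N)cc2)cc1`) gives 70.7% and lies higher, beyond the scatter.

Compound 3 (`Nc1ccccc1NC(=O)/C=C/c1ccc(CSc2ccc(F)cc2)cc1`) has not yet been measured. It keeps the core of compound 1 and changes one group (4-fluorophenyl in place of 3-fluorophenyl on a sulfur) with 4-fluorophenyl in place of 3-fluorophenyl on a sulfur. The two compounds have the same atoms, joined differently.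

For the measured compounds named here, no measured pair shows what this change does, so the size of the step cannot be read from the data. The working expectation is no step beyond the scatter in this assay, and the estimate is anchored on compound 1 at 56.6% alone. The expected step (a number 1.4 percentage points higher from compound 1 to compound 3 (within the scatter)) is therefore small, with neither direction favoured. For compound 3 the estimated value is 58% with an expected range from 42% to 73% in this single-concentration read-out.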

Compound 3, percent growth inhibition at one concentration: 59.1%
For compound 3 the middle estimate is 1.1 percentage points below the measured one; the range from low to high includes it.
By their numbers in this assay, from the lowest: compounds 1 and 3 (each within the scatter of the next); then compound 2.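

For the compounds shown here, the first step that can be read at this place is a number 2.5 percentage points higher from compound 1 to compound 3 (within the scatter) in this assay, for 4-fluorophenyl in place of 3-fluorophenyl on a sulfur. For this one pair, on the core of compound 1, the two fluorophenyl isomers cannot be told apart at the single concentration tested, so this read-out gives no reason to prefer either group, and the finding does not extend beyond these two compounds. No independent measurement bears on this result.

Still open, as far as these compounds go, is how much the group on sulfur matters at all, since both compounds carry a fluorophenyl and the step says nothing about a larger change, such as an unsubstituted phenyl, a carboxylic acid or an amine on that ring, or a longer chain in its place. A single concentration also leaves open whether compound 1 and compound 3 would remain indistinguishable across a full concentration range or in other cell lines.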